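The compounds below may be only part of what the source reports. "The series", "measured", "known", "first", "only" and "open" are said of these compounds alone.

The three measured compounds share one core and differ in the group on an aromatic carbon of the fused ring system. Compound 1 `COc1ccc(Oc2ccc3c(NCCCNCc4cc(F)ccc4OC)ccnc3c2)cc1` gives 7000 nM in an ADME assay on HepG2 cells (Homo sapiens) for cytotoxicity, read by luminescence, CellTiter-Glo and ATP content, with a stated time of 72 h; on this read-out higher numbers stand for an effect only at larger amounts of compound and lower numbers for an effect already at smaller amounts. Compound 2 `c1ccc(Oc2ccc3c(NCCCNCc4ccco4)ccnc3c2)cc1` gives 15200 nM in this assay, and compound 3 `COc1ccc(F)cc1CNCCCNc1ccnc2cc(CC(C)C)ccc12` gives 2900 nM in this assay. On these numbers compound 2 stands highest: the nearest is compound 1, and the furthest is compound 3, both of them beyond the scatter.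

The compound to be considered next is compound 4 `Cc1cc(C)cc(Cc2ccc3c(NCCCNCc4ccco4)ccnc3c2)c1`, which differs from compound 2 in one place: 3,5-dimethylbenzyl in place of phenoxy on an aromatic carbon.

For the measured compounds named here, only one measured step bears on this change. It is the step of a 2.4-fold lower number from compound 1 to compound 3 (0.38 log units; beyond the scatter), where an aryloxy group was likewise replaced by a carbon-only group on the same aromatic carbon of the core, and the number fell by a modest amount. The change from compound 2 to compound 4 is of the same kind, so a step of similar size and in the same direction is expected in this assay: the number for compound 4 is expected to be lower than that of compound 2, by a modest margin that is nonetheless beyond the scatter. Compound 4 is therefore estimated at 6500 nM, with a range from 2500 nM to 18000 nM, which corresponds to an expected step of a 2.3-fold lower number from compound 2 to compound 4 (0.37 log units; beyond the scatter).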

Compound 4, half-maximal effective concentration: 6270 nM
Beside the measured number, compound 4's estimate is 1.0-fold (0.02 log units) above it; the measured number falls inside the stated range.
By their numbers in this assay, from the lowest: compound 3; then compounds 4 and 1 (each within the scatter of the next); then compound 2.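

In this assay, replacing phenoxy with 3,5-dimethylbenzyl on this aromatic carbon gives a 2.4-fold lower number from compound 2 to compound 4 (0.38 log units; beyond the scatter), in the same direction as a 2.4-fold lower number from compound 1 to compound 3 (0.38 log units; beyond the scatter), so a modest fall on leaving an aryloxy group for a carbon-only group now appears in two pairs that carry different side chains on the shared core. The earlier step also removed the aromatic ring, since isobutyl has none, whereas 3,5-dimethylbenzyl retains one six-membered aromatic ring of carbon only; in these compounds, therefore, a lower number does not depend on losing that ring. No measurement is available to explain why the number falls with this change.

The compounds shown leave open whether the step follows from losing the oxygen of phenoxy or from adding the two methyl groups and the larger group, a question that plain benzyl at this position could separate. They also leave open how a group carrying an amine or a carboxylic acid at this position would read in this assay.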